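The source may hold more compounds than are shown below. What is called first, only, known or untested is meant among the compounds shown, and "the series" means these compounds.

Of the compounds shown here, two have so far been measured in an assay on CHO cells for displacement of a labelled ligand from adenosine receptor A3 (Homo sapiens); a higher number here means a weaker inhibitor, a lower number a stronger inhibitor. Compound 1 `CNc1ncc(C(=O)O)c2nc(-c3ccco3)nn12` gives 15900 nM. Compound 2 `COc1ccc(CNc2ncc(C(=O)O)c3nc(-c4ccco4)nn23)cc1` gives 5520 nM. Among the compounds with values here, the one step between them, a 2.9-fold lower number from compound 1 to compound 2 (0.46 log units; beyond the scatter), comes from a 4-methoxyphenyl in place of hydrogen on a saturated chain carbon bound to a nitrogen on an aromatic ring. Within the data shown here, on these two numbers compound 2 stands lowest, with compound 1 as its only neighbour, a step apart as just told.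

Compound 3 `O=C(O)c1cnc(NCc2ccc(F)cc2)n2nc(-c3ccco3)nc12` has not yet been measured. It differs from compound 2 in a single place: fluoro in place of methoxy on an aromatic carbon, on an aromatic carbon of a six-membered aromatic ring of carbon only, para to a large group. Among the measured compounds shown here, none of the measured steps bears directly on this change; the only step known, the one from compound 1 to compound 2, introduced the whole 4-methoxyphenyl group rather than altering what sits on it. With nothing to lean on, compound 3 is expected to shift by a 1.1-fold higher number from compound 2 to compound 3 (0.04 log units; within the scatter), a step within the scatter. Compound 3 is therefore estimated at 6000 nM, with a range from 2500 nM to 14000 nM.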

Compound 3, inhibition constant: 14000 nM
Beside the measured number, compound 3's estimate is 2.3-fold (0.37 log units) below it; the measured number falls inside the stated range.
By their numbers in this assay, from the lowest: compound 2; then compounds 3 and 1 (each within the scatter of the next).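

In this assay the group on this aromatic carbon, para to a large group, makes a difference: fluoro in place of methoxy brings a 2.5-fold higher number from compound 2 to compound 3 (0.40 log units; beyond the scatter). Going the other way round the series, the 4-fluorophenyl group in place of hydrogen on the chain carbon brings a 1.1-fold lower number from compound 1 to compound 3 (0.06 log units; within the scatter), so the lower number reached with the 4-methoxyphenyl group does not appear with the 4-fluorophenyl group, and a substituted phenyl ring on that carbon is not enough by itself. Nothing measured here explains why methoxy and fluoro part in this way.

Within the data shown here, with only two groups compared on this ring carbon, it stays open whether the lower number belongs to methoxy in particular or would also come with ethoxy, hydroxy, chloro or methyl, or with no group there at all. As far as these compounds go, all three compounds also carry the same carboxylic acid on the shared core, so what a methyl ester or an amide in its place would do to these numbers is unknown.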